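An Amino Group Added to a Fused Two-Ring Anticonvulsant Core

The source may report more compounds than this note shows. Statements on the series, on what has been measured and on what is new or still open speak of the compounds shown alone.

Measured compounds:
Compound 1, `Cc1nn2cnnc2cc1Cc1ccccc1Cl`: 6 mg/kg
Compound 2, `Cc1nn2cnnc2cc1Cc1c(Cl)cccc1Cl`: 6.2 mg/kg

Both were tested in a functional assay on the whole organism with Mus musculus as the target, in the maximal electroshock model; a higher number here means that more compound is needed for the effect, a lower number that less compound is needed. Compound 1 gives 6 mg/kg, and compound 2 gives 6.2 mg/kg. Going by the values given here, the two numbers lie within the usual scatter of each other, so compound 2 stands beside compound 1 rather than apart from it; the only measured step, a 1.0-fold higher number from compound 1 to compound 2 (0.01 log units; within the scatter), reflects the added chloro on the pendant ring.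

Compound 3, `Cc1nn2c(N)nnc2cc1Cc1c(Cl)cccc1Cl`, has not yet been measured. It differs from compound 2 in one place: amino in place of hydrogen on an aromatic carbon. Among the compounds with values here, no measured step touches this part of the shared core, and the one step that exists changed a different ring and came out flat. There is thus no direct evidence pointing up or down for this new change.

Given that, compound 3 is expected to give about 6 mg/kg in this assay, within a range from 2.5 mg/kg to 15 mg/kg. This corresponds to an estimated step of a 1.0-fold lower number from compound 2 to compound 3 (0.01 log units; within the scatter), with the uncertainty deliberately set wide.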

Compound 3, dose for half-maximal effect: 9.2 mg/kg
Beside the measured number, compound 3's estimate is 1.5-fold (0.19 log units) below it; the measured number falls inside the stated range.
By their numbers in this assay, from the lowest: compounds 1, 2 and 3 (each within the scatter of the next).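

In this assay the step is a 1.5-fold higher number from compound 2 to compound 3 (0.17 log units; within the scatter) and so lies within the scatter: an amino group on this aromatic carbon of the five-membered aromatic ring, between two ring nitrogen atoms, leaves compound 3 level with compound 2 as far as this test can tell. Going by these compounds alone, this is the first reading from the shared core itself, since the earlier step concerned only a chloro on the pendant ring, and it shows that this carbon can carry a group with a hydrogen-bond donor while the compound stays active in the whole animal at a dose comparable to that of compound 2. What the amino group does at this position, and why the number stays within the scatter, finds no support in any measurement at hand.

Still open, going by these compounds, is whether this carbon accepts more than a single nitrogen, for example a methylamino or dimethylamino group, or a different small group such as methyl or hydroxyl. Also open, on these data alone, is whether the same amino group would behave alike on compound 1, which carries one chloro on the pendant ring rather than two.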